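The source may hold more compounds than are shown below. What is called first, only, known or untested is meant among the compounds shown, and "the series" means these compounds.

Measured so far:
Compound 1, `Cc1ncc([N+](=O)[O-])n1CCOc1ccc(F)cc1`: 85.8 ug/mL
Compound 2, `Cc1ncc([N+](=O)[O-])n1CCOc1ccc([N+](=O)[O-])cc1`: 127 ug/mL

Both compounds share one core and differ only in the group on the six-membered aromatic ring of carbon only. In a functional assay on MCF7 cells (Homo sapiens) for cytotoxicity, read by MTT assay, with a stated time of 24 h (a higher number here means a weaker inhibitor, a lower number a stronger inhibitor), compound 1 gives 85.8 ug/mL, while compound 2 gives 127 ug/mL. Compound 2 sits at one end of the two numbers shown, but the single measured step, a 1.5-fold higher number from compound 1 to compound 2 (0.17 log units; within the scatter), means the two compounds cannot be told apart in this assay.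

Compound 3, `Cc1ncc([N+](=O)[O-])n1CCOc1ccc(C#N)cc1`, has not yet been measured. It differs from compound 2 in one place: cyano in place of nitro on an aromatic carbon. Going by the values given here, the only step that bears on this change is the one already described, an exchange of groups at the same place that stayed within the scatter. On that basis no step beyond the scatter is expected for compound 3 in this assay. For compound 3 the expected step is a 1.2-fold lower number from compound 2 to compound 3 (0.08 log units; within the scatter). Compound 3 is therefore estimated to give 105 ug/mL, in the range 55 ug/mL to 200 ug/mL.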

Compound 3, half-maximal inhibitory concentration: 83.2 ug/mL
Estimate against measurement, compound 3: 1.3-fold (0.10 log units) above; measured number inside the range.
By their numbers in this assay, from the lowest: compounds 3, 1 and 2 (each within the scatter of the next).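

In this assay the cyano compound adds a third group at the same place on the six-membered aromatic ring of carbon only, para to a large group. The new steps are a 1.5-fold lower number from compound 2 to compound 3 (0.18 log units; within the scatter) and a 1.0-fold lower number from compound 1 to compound 3 (0.01 log units; within the scatter) and both stay within the scatter. Fluoro, nitro and cyano therefore cannot be told apart at this place, although nitro and cyano differ in heavy atoms and in bond type, and nothing shown gives a reason for this.

Still open, going by these compounds, is whether a group of another kind at this place, such as an amine or a carboxylic acid, would give a step beyond the scatter. Also open, on these data alone, is whether a longer chain on the shared core would do so.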